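Methylphenyl swap on the ring nitrogen: cytotoxicity notes

A few compounds are considered here, and "the series" means these few. Any claim that something is new, unique, unknown or untested is made for them only; others in the source may bear on it.

Among the compounds with values here, the series so far holds three measured sulfonamides. Compound 1 `Cc1ccc(-n2cc(-c3ccccc3NS(=O)(=O)c3c[nH]c(=O)[nH]c3=O)nn2)cc1` is one of them. In an ADME assay on L02 cells (Homo sapiens) for cytotoxicity, read by MTT assay, with a stated time of 24 h (on this read-out lower numbers stand for higher toxicity in this test and higher numbers for lower toxicity in this test), compound 1 gives > 100000 nM, which is a limit of the test and not a number. Compound 2 `O=c1[nH]cc(S(=O)(=O)Nc2ccccc2-c2cn(-c3cccc(F)c3)nn2)c(=O)[nH]1` is the second. In this assay compound 2 is reported as "not toxic" (no number reported) with no number attached. Compound 3 `Cc1ccccc1-n1cc(-c2cccc(NS(=O)(=O)c3c[nH]c(=O)[nH]c3=O)c2)nn1` is the third and the only one with a single number shown: in this assay compound 3 gives 15300 nM. Against these, compound 3 stands as the sole quantified value, with compound 1 sitting at the limit of > 100000 nM in this assay, at which 1 of the 3 values shown sits, and compound 2 without a number.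

Compound 4 `Cc1ccc(-n2cc(-c3cccc(NS(=O)(=O)c4c[nH]c(=O)[nH]c4=O)c3)nn2)cc1` is not yet measured. It differs from compound 3 in one place: 4-methylphenyl in place of 2-methylphenyl on an aromatic nitrogen. Within the data shown here, no step between two measured compounds is available to calibrate such a change. Because the single number of compound 3 is 15300 nM and no other single number is shown in the series, the expected step from compound 3 to compound 4 is a 2.0-fold higher number from compound 3 to compound 4 (0.29 log units; within the scatter), no larger than the usual scatter or a small shift toward lower toxicity. Compound 4 is therefore estimated at 30000 nM, within the range 10000 nM to 100000 nM.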

Compound 4, half-maximal cytotoxic concentration: 23100 nM
For compound 4 the middle estimate is 1.3-fold (0.11 log units) above the measured one; measured number inside the range.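

The series now has its first step between two measured compounds that differ in one place, and in this assay that step reads a 1.5-fold higher number from compound 3 to compound 4 (0.18 log units; within the scatter) for the exchange on the aromatic nitrogen of the five-membered ring. With the same atoms joined differently, 2-methylphenyl and 4-methylphenyl cannot be told apart on this read-out, and compound 3 and compound 4 both give a single number rather than a limit, so this position now has one calibrated exchange that stays inside the usual scatter. No measurement shown bears on the reason for this outcome, and the single step gives no basis for a wider rule about this position.

Still open, from the compounds shown here alone, is whether a group of another kind on that phenyl ring, such as a carboxylic acid, an amine or a longer chain in place of the methyl, would move the number in this assay beyond the scatter. In this assay compound 1 gives > 100000 nM, which is a limit of the test and not a number, and no size of step can be read from it.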